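Fluoro anilinopyrimidine acrylamides: shortening the imidazole linker

A few compounds are considered here, and "the series" means these few. Any claim that something is new, unique, unknown or untested is made for them only; others in the source may bear on it.

The series shares the acrylamide-bearing core of compound 1 `C=CC(=O)Nc1cccc(Nc2nc(Nc3ccc(OCCn4ccnc4)cc3)ncc2Cl)c1`, which in a functional assay on A549 cells (Homo sapiens) for antiproliferative activity, read by MTT assay, with a stated time of 48 h (on this read-out higher numbers stand for weaker inhibition and lower numbers for stronger inhibition), gives 8440 nM. Going by the values given here, its fluoro analogue, compound 2 `C=CC(=O)Nc1cccc(Nc2nc(Nc3ccc(OCCn4ccnc4)cc3)ncc2F)c1`, gives 8370 nM, and the single change between them, a 1.0-fold lower number from compound 1 to compound 2 (0.00 log units; within the scatter), is the only step that the three measured compounds offer. Among the compounds with values here, compound 3 `C=CC(=O)Nc1cccc(Nc2nc(Nc3ccc(Cn4ccnc4)cc3OC)ncc2Cl)c1` carries a methoxy group as well as the shorter imidazole linker and gives 14300 nM; its number and that of compound 2 lie within the scatter of each other, as do all three values, so no compound can be set apart as more or less active.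

Compound 4 `C=CC(=O)Nc1cccc(Nc2nc(Nc3ccc(Cn4ccnc4)cc3)ncc2F)c1` differs from compound 2 by (1H-imidazol-1-yl)methyl in place of 2-(1H-imidazol-1-yl)ethoxy on an aromatic carbon. Within the data shown here, no measured pair isolates this change: the only comparison containing the (1H-imidazol-1-yl)methyl group, compound 3 against compound 2, also differs in the methoxy group and the halogen, and shows a gap within the scatter. Among the measured compounds shown here, with the one measured step, from compound 1 to compound 2, flat, and no direct precedent for the linker change, no step beyond the scatter is expected. Compound 4 is therefore estimated at 10000 nM, between 4000 nM and 25000 nM, meaning an expected 1.2-fold higher number from compound 2 to compound 4 (0.08 log units; within the scatter).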

Compound 4, half-maximal inhibitory concentration: 3560 nM
For compound 4 the middle estimate is 2.8-fold (0.45 log units) above the measured one; measured number outside the range, below it.
By their numbers in this assay, from the lowest: compound 4; then compounds 2, 1 and 3 (each within the scatter of the next).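

In this assay the (1H-imidazol-1-yl)methyl group gives a 2.4-fold lower number from compound 2 to compound 4 (0.37 log units; beyond the scatter) and so brings modestly stronger inhibition. Going by these compounds alone, this is the first single change to lie beyond the scatter, which marks the group on an aromatic carbon para to a large group as a place where a change registers, whereas the halogen swap, a 1.0-fold lower number from compound 1 to compound 2 (0.00 log units; within the scatter), did not. No measurement shown here bears on the reason for this step.

The change shortens the link and removes the ether oxygen together, so this single pair cannot tell which of the two carries the step, and a 2-(1H-imidazol-1-yl)ethyl group, which keeps the longer chain without the oxygen, would separate them. Also open, on these data alone, are whether the step holds with chloro in place of fluoro, and whether a basic amine such as morpholine or piperazine on the same methyl link would serve in place of the imidazole.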